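The source may report more compounds than this note shows. Statements on the series, on what has been measured and on what is new or still open speak of the compounds shown alone.

Measured compounds:
compound 1 `CN1CCN(Cc2ccc(Nc3nc(Oc4ccc5ccc(=O)[nH]c5c4)c4sccc4n3)cc2)CC1` — 19300 nM
compound 2 `CCN1CCN(c2nc(Oc3ccc4ccc(=O)[nH]c4c3)c3sccc3n2)CC1` — "not determined" (no result reported)

Going by the values given here, compound 1 gives the only number in a functional assay on PC-9 cells (Homo sapiens) for antiproliferative activity, read by MTT assay, with a stated time of 72 h (a lower number here means a stronger inhibitor, a higher number a weaker inhibitor), standing at 19300 nM, a weak result; compound 2 has no number reported in this assay. Compound 3 `CCN1CCN(Cc2ccc(Nc3nc(Oc4ccc5ccc(=O)[nH]c5c4)c4sccc4n3)cc2)CC1` is compound 1 with one alteration: methyl in place of hydrogen on a saturated chain carbon bound to an amine nitrogen in a ring. Among the compounds with values here, no step between measured compounds is available to guide this change, so the expected step from compound 1 to compound 3 in this assay is small, with no direction beyond the usual scatter, as a 1.0-fold lower number from compound 1 to compound 3 (0.01 log units; within the scatter) shows. Compound 3 is therefore estimated at 19000 nM, within a range from 8000 nM to 45000 nM.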

Compound 3, half-maximal inhibitory concentration: 17500 nM
Compound 3: the middle estimate sits 1.1-fold (0.04 log units) above what was measured; the measured number falls inside the stated range.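

Going by these compounds alone, the step of a 1.1-fold lower number from compound 1 to compound 3 (0.04 log units; within the scatter) in this assay gives the first measured reading at this position: on the saturated chain carbon bound to an amine nitrogen in a ring, exchanging hydrogen for methyl, which turns 4-methylpiperazin-1-yl into 4-ethylpiperazin-1-yl, stays within the scatter. No measured evidence bears on this result.

From the compounds shown here alone, whether a longer chain such as propyl, or a hydroxyethyl or acetyl group, at this position would also stay within the scatter remains open. So does whether any change elsewhere on the core would move the number.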